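Swapping bromo for chloro on the aryl ring of compound 3

A few compounds are considered here, and "the series" means these few. Any claim that something is new, unique, unknown or untested is made for them only; others in the source may bear on it.

Measured so far:
Compound 1, `CCOc1ccc(Br)cc1C(C)NC(=O)N(C)S(=O)(=O)c1ccc(Cl)cc1`, 55700 nM
Compound 2, `COc1ccc(Br)cc1C(C)NC(=O)N(C)S(=O)(=O)c1ccc(C)cc1`, 19100 nM
Compound 3, `CCOc1ccc(Br)cc1C(C)NC(=O)N(C)S(=O)(=O)c1ccc(C)cc1`, 28600 nM

These three sulfonylureas were tested in a functional assay on thoracic aorta (Rattus norvegicus, strain Wistar), with a stated time of 15 min; a lower number here means that less compound is needed, a higher number that more compound is needed for the effect. Compound 3 stands second highest of the three numbers; its nearest neighbour is compound 2 with a 1.5-fold higher number from compound 2 to compound 3 (0.18 log units; within the scatter), its furthest compound 1 with a 1.9-fold lower number from compound 1 to compound 3 (0.29 log units; within the scatter), both within the scatter.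

Compound 4, `CCOc1ccc(Cl)cc1C(C)NC(=O)N(C)S(=O)(=O)c1ccc(C)cc1`, differs from compound 3 by chloro in place of bromo on an aromatic carbon. Within the data shown here, no measured step changes this halogen; the two known steps touch other parts of the shared core and neither moved the number beyond the scatter. With nothing pointing in either direction, the estimate for compound 4 is no change at the digits printed from compound 3 to compound 4 (within the scatter), and compound 4 is expected to give 28600 nM, within 12000 nM to 70000 nM.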

Compound 4, half-maximal effective concentration: 12200 nM
For compound 4 the middle estimate is 2.3-fold (0.37 log units) above the measured one; measured number inside the range.
By their numbers in this assay, from the lowest: compounds 4, 2, 3 and 1 (each within the scatter of the next, the first and the last beyond it).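

At this position, para to an ethoxy group, the halogen matters in this assay: a 2.3-fold lower number from compound 3 to compound 4 (0.37 log units; beyond the scatter) is a modest step, yet it is the only single change shown that lies beyond the scatter. The two earlier steps, on the other aromatic ring and on the ethoxy chain, stayed within it. Nothing available explains why chloro and bromo differ here.

Going by these compounds, how fluoro, a nitrile or an amine would fare at this position remains open. So does whether the gain from chloro carries over to the cores of compound 1 and compound 2.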